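The source may hold more compounds than are shown below. What is called first, only, known or untested is meant among the compounds shown, and "the series" means these compounds.

Compound 1 `CC[C@H](C)[C@H]1C(=O)N[C@H](Cc2cc(Cl)c(O)c(Cl)c2)C(=O)N[C@@H](C(C)C)C(=O)O[C@H](c2ccccc2)[C@H](C)/C=C/C=C(\C)[C@H](OC)C[C@@H]2O[C@@]2(C)C(=O)N1C` and compound 3 `CC[C@H](C)[C@H]1C(=O)N[C@H](Cc2cc(Cl)c(O)c(Cl)c2)C(=O)N[C@@H](C(C)C)C(=O)O[C@H](c2ccccc2)[C@H](C)/C=C/C=C(\C)[C@H](OC)C/C=C(\C)C(=O)N1C` share a core that differs in more than one place between them; the difference between the two cores is not broken down here. In a functional assay on PANC-1 cells (Homo sapiens) for antiproliferative activity (on this read-out lower numbers stand for stronger inhibition and higher numbers for weaker inhibition), compound 1 gives 15.5 nM, while compound 3 gives 137 nM, the highest number of the three measured compounds and well beyond the scatter from compound 1.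

Compound 2 `CC[C@H](C)[C@H]1C(=O)N[C@H](Cc2cc(Cl)c(O)c(Cl)c2)C(=O)N[C@@H](C(C)(C)O)C(=O)O[C@H](c2ccccc2)[C@H](C)/C=C/C=C(\C)[C@H](OC)C[C@@H]2O[C@@]2(C)C(=O)N1C` carries the change hydroxy in place of hydrogen on a saturated chain carbon bound to two saturated chain carbons and a saturated ring carbon on the core of compound 1. In this assay compound 2 gives 12.2 nM, so the step is a 1.3-fold lower number from compound 1 to compound 2 (0.10 log units; within the scatter).

Compound 4 `CC[C@H](C)[C@H]1C(=O)N[C@H](Cc2cc(Cl)c(O)c(Cl)c2)C(=O)N[C@@H](C(C)(C)O)C(=O)O[C@H](c2ccccc2)[C@H](C)/C=C/C=C(\C)[C@H](OC)C/C=C(\C)C(=O)N1C` carries the same change, (hydroxy in place of hydrogen on a saturated chain carbon bound to two saturated chain carbons and a saturated ring carbon), on the core of compound 3; the place of the change is identical in both pairs. For the measured compounds named here, since the one earlier instance of this change left the read-out essentially unmoved, the step from compound 3 to compound 4 in this assay is expected to be a 1.2-fold lower number from compound 3 to compound 4 (0.10 log units; within the scatter), sitting beside the earlier step rather than away from it. Compound 4 is therefore estimated at 110 nM, with a range from 55 nM to 230 nM.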

Compound 4, half-maximal inhibitory concentration: 11.3 nM
Compound 4: the middle estimate sits 9.7-fold (0.99 log units) above what was measured; the measured number lies below the stated range.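

In this assay the change from isopropyl to 1-hydroxy-1-methylethyl gives a 12-fold lower number from compound 3 to compound 4 (1.08 log units; beyond the scatter), so on the core of compound 3 this single change moves the read-out well beyond the scatter. Set beside the earlier step, the same change does not carry over with a constant size from one core to the other: the same change on two cores in this assay, a 1.3-fold lower number (0.10 log units; within the scatter) from compound 1 to compound 2 and a 12-fold lower number (1.08 log units; beyond the scatter) from compound 3 to compound 4, 9.5-fold (0.98 log units) apart, beyond the scatter of two such steps. The size of the step therefore depends on the core in these two pairs, but two pairs do not show which of the several differences between the cores accounts for the gap, nor what size the step would take on any further core.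

Still open, from the compounds shown here alone, is whether an amine or a fluorine on that saturated chain carbon would give the same contrast between the two cores as hydroxy does. Equally open, going by these compounds, is whether a longer chain in place of the isopropyl would separate the two cores in this way.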